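A few compounds are considered here, and "the series" means these few. Any claim that something is new, unique, unknown or untested is made for them only; others in the source may bear on it.

Compound 1 `O=C1/C(=C/c2ccccc2)CCC/C1=C\c1ccc(O)cc1` gives 53% in an assay on isolated protein for inhibition of Alpha glucosidase (Homo sapiens), with stated times of 5 min and 15 min, tested at 50 uM; a lower number here means less inhibition, a higher number more inhibition at the concentration tested (going by the name of the read-out). Compound 2 `O=C1/C(=C/c2ccccc2)CCC/C1=C\c1ccc(F)cc1` gives 34% in the same assay, a change of a number 19 percentage points lower from compound 1 to compound 2 (beyond the scatter). Compound 3 `O=C1/C(=C/c2ccccc2)CCC/C1=C\c1ccccc1F` gives 43%; the steps of a number 10 percentage points lower from compound 1 to compound 3 (within the scatter) and a number 9 percentage points higher from compound 2 to compound 3 (within the scatter) are both within the scatter, so compound 3 stands between the other two without being separable from either.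

Compound 4 `O=C1/C(=C/c2ccccc2)CCC/C1=C\c1ccccc1Br` differs from compound 3 by bromo in place of fluoro on an aromatic carbon. Within the data shown here, none of the measured steps exchanges one halogen for another on the aromatic carbon: the step from compound 1 to compound 2 concerns fluoro replacing hydroxy, and the step from compound 2 to compound 3 concerns where fluoro sits. The measured steps therefore give no direct guide, and the three numbers span a narrow band, so no step beyond the scatter is expected from compound 3 to compound 4, with a number 2 percentage points higher from compound 3 to compound 4 (within the scatter) as the expected change. Compound 4 is thus estimated at 45% in this assay, in a range from 30% to 60%.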

Compound 4, a percentage reported as inhibition, at one concentration (the size of the read-out at that concentration, not a potency): 46.8%
For compound 4 the middle estimate is 1.8 percentage points below the measured one; the measured number falls inside the stated range.
By their numbers in this assay, from the lowest: compounds 2, 3, 4 and 1 (each within the scatter of the next, the first and the last beyond it).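

In this assay bromo in place of fluoro, on an aromatic carbon ortho to a large group, gives a number 3.8 percentage points higher from compound 3 to compound 4 (within the scatter) so the two halogens cannot be told apart at this place. Unlike compound 3, compound 4 separates from compound 2, with a number 12.8 percentage points higher from compound 2 to compound 4 (beyond the scatter) as the step, while a number 6.2 percentage points lower from compound 1 to compound 4 (within the scatter) leaves it unseparated from compound 1. That separation still does not set bromo apart from fluoro: compound 3 and compound 4 remain within the scatter of each other.

From the compounds shown here alone, whether an amine, a methoxy group or a carboxylic acid at this place would move the number beyond the scatter of compound 3 stays open. No measurement at hand accounts for the numbers seen here.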